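One side group changes on a shared core

The source may hold more compounds than are shown below. What is called first, only, known or untested is meant among the compounds shown, and "the series" means these compounds.

Compound 1 (`CCOC(=O)C1=C(N/N=C(\C#N)C(N)=O)Nc2[nH]nc(C)c2C1c1ccc(N(C)C)cc1`), compound 2 (`CCOC(=O)C1=C(N/N=C(/C(=O)Br)c2ccc(Br)cc2)Nc2[nH]nc(C)c2C1c1ccc(N(C)C)cc1`) and compound 3 (`CCOC(=O)C1=C(N/N=C(/Br)c2ccccc2)Nc2[nH]nc(C)c2C1c1ccc(N(C)C)cc1`) share one core and differ in the group on an amine nitrogen. In a functional assay on HeLa cells (Homo sapiens) for inhibition, read by MTT assay, with a stated time of 48 h (on this read-out lower numbers stand for stronger inhibition and higher numbers for weaker inhibition), compound 1 gives 47300 nM while compound 2 gives 68500 nM and compound 3 gives 75700 nM as its reading. These numbers lie within the scatter of one another, so compound 3 stands level with the other two and no ranking can be read from them.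

Compound 4 (`CCOC(=O)C1=C(N/C=N/c2ccc(C)cc2)Nc2[nH]nc(C)c2C1c1ccc(N(C)C)cc1`) keeps the core and changes that group: a group of 9 heavy atoms (8 carbon, 1 nitrogen; one six-membered aromatic ring of carbon only) in place of a group of 9 heavy atoms (7 carbon, 1 nitrogen, 1 bromine; one six-membered aromatic ring of carbon only), on an amine nitrogen on an amine nitrogen whose other neighbours are: double-bonded ring carbon. The entering group carries no bromine.

Going by the values given here, three measured steps bear on this change, since each swaps the group at that same place. They are a 1.4-fold higher number from compound 1 to compound 2 (0.16 log units; within the scatter) and a 1.6-fold higher number from compound 1 to compound 3 (0.20 log units; within the scatter) and a 1.1-fold higher number from compound 2 to compound 3 (0.04 log units; within the scatter) and all of them stay within the scatter. No step beyond the scatter is therefore expected in this assay and no clear direction either. The estimated change is a 1.3-fold lower number from compound 3 to compound 4 (0.10 log units; within the scatter) and should not be read as a real shift. For compound 4 the estimated value is 60000 nM with an expected range from 25000 nM to 140000 nM in this measurement.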

Compound 4, half-maximal inhibitory concentration: 43200 nM
For compound 4 the middle estimate is 1.4-fold (0.14 log units) above the measured one; the range from low to high includes it.
By their numbers in this assay, from the lowest: compounds 4, 1, 2 and 3 (each within the scatter of the next).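

Going by these compounds alone, until now, the two groups with an aromatic ring, in compounds 2 and 3, also carried bromine, while the one group without bromine, in compound 1, had no ring, so the ring and the bromine could not be told apart. The group in compound 4 has the ring without the bromine, and this assay gives a 1.8-fold lower number from compound 3 to compound 4 (0.24 log units; within the scatter) and a 1.6-fold lower number from compound 2 to compound 4 (0.20 log units; within the scatter), while the comparison with the ringless group gives a 1.1-fold lower number from compound 1 to compound 4 (0.04 log units; within the scatter). Among these four compounds, then, removing the bromine while keeping the ring leaves the reading within the scatter, and so does having this ring-bearing group rather than the ringless one.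

Whether any group on this amine nitrogen can move the reading beyond the scatter stays open, since a carboxylic acid, a simple amine or a longer alkyl chain at this place is not among the compounds shown. No measurement shown here bears on why the four readings lie so close together.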